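The compounds below may be only part of what the source reports. "The series", "measured", "known", "first", "only" and "open" are said of these compounds alone.

Compound 1 `CCOC(=O)N1CCC(=NNC(=O)c2ccc(C)cc2)CC1` and compound 2 `CCOC(=O)N1CCC(=NNC(=O)c2ccc(C(F)(F)F)cc2)CC1` are built on one core. In a functional assay, read by spectrophotometry (on this read-out lower numbers stand for stronger inhibition and higher numbers for weaker inhibition), compound 1 gives 28100 nM, and compound 2 gives 23500 nM. The change between them is trifluoromethyl in place of methyl on an aromatic carbon, and it made a step of a 1.2-fold lower number from compound 1 to compound 2 (0.08 log units; within the scatter).

Compound 3 `Cc1ccc(C(=O)NN=C2CC(c3ccccc3)NC(c3ccccc3)C2)cc1` has a different core; how the two cores differ is not broken down here. In this assay compound 3 gives 64100 nM. Compound 4 `O=C(NN=C1CC(c2ccccc2)NC(c2ccccc2)C1)c1ccc(C(F)(F)F)cc1` differs from compound 3 by trifluoromethyl in place of methyl on an aromatic carbon, the same change, at the same kind of place, as from compound 1 to compound 2.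

Because that earlier change produced only a 1.2-fold lower number from compound 1 to compound 2 (0.08 log units; within the scatter), the step of a 1.2-fold lower number from compound 3 to compound 4 (0.07 log units; within the scatter) is expected to stay small as well, though the core here is different and a single example is a thin basis. Compound 4 is therefore estimated at 55000 nM, likely between 25000 nM and 120000 nM.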

Compound 4, half-maximal inhibitory concentration: 153000 nM
Compound 4: the middle estimate sits 2.8-fold (0.44 log units) below what was measured; measured number outside the range, above it.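

Trifluoromethyl in place of methyl gave a 2.4-fold higher number from compound 3 to compound 4 (0.38 log units; beyond the scatter) in this assay, a modest move towards weaker inhibition, and this step does not match the one seen on the other core: the same change on two cores in this assay, a 1.2-fold lower number (0.08 log units; within the scatter) from compound 1 to compound 2 and a 2.4-fold higher number (0.38 log units; beyond the scatter) from compound 3 to compound 4, 2.9-fold (0.46 log units) apart, beyond the scatter of two such steps

In this series, then, the size of this step on one core cannot simply be carried over to the other. Among the compounds shown here, with only one pair on each core, this does not show which part of the cores matters, why the steps differ, or how any other change would carry across.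

As far as these compounds go, it remains open how other groups in the same place, such as a nitrile or a methoxy group, would behave on each core. A single further pair on either core could show whether the gap between the steps extends beyond this one change.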